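The source may hold more compounds than are shown below. What is called first, only, known or untested is meant among the compounds shown, and "the series" means these compounds.

Measured compounds:
- compound 1 `O=C(Nc1ccc(Cl)c(-c2nnc3c(Cl)cccn23)c1)c1ccc(Cl)cc1`; in a functional assay on MDA-MB-231 cells (Homo sapiens) for antiproliferative activity, read by MTT assay, with stated times of 72 h and 4 h (on this read-out lower numbers stand for stronger inhibition and higher numbers for weaker inhibition), compound 1 gives > 100000 nM
- compound 2 `CS(=O)(=O)c1cccc(C(=O)Nc2ccc(Cl)c(-c3nnc4c(Cl)cccn34)c2)c1`; in this assay compound 2 gives > 100000 nM
- compound 3 `CS(=O)(=O)c1ccc(C(=O)Nc2ccc(Cl)c(-c3nnc4c(Cl)cccn34)c2)cc1`; in this assay compound 3 gives > 100000 nM

Each of these three values is a limit of the assay, not a number; all sit at the same limit (the limit of > 100000 nM in this assay, at which 3 of the 3 values shown sit). Compound 3 therefore stands only at a limit, with nothing to rank it against compound 1 or compound 2. The three steps between them are accordingly unreadable: a step that the two limits leave unreadable from compound 1 to compound 2, a step that the two limits leave unreadable from compound 1 to compound 3 and a step that the two limits leave unreadable from compound 2 to compound 3.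

Compound 4 `O=C(Nc1ccc(Cl)c(-c2nnc3c(Cl)cccn23)c1)c1ccc(F)cc1Cl` differs from compound 3 by 2-chloro-4-fluorophenyl in place of 4-(methylsulfonyl)phenyl on a carbonyl carbon. Going by the values given here, no measured step bears readably on this change. Compound 1, which also carries a chlorine-bearing phenyl on the carbonyl carbon, sits at that same limit (the limit of > 100000 nM in this assay, at which 3 of the 3 values shown sit). The expectation for compound 4 is therefore another limit rather than a readable value, with the expected step of a number no higher from compound 3 to compound 4 (the limit leaves the size open) being none beyond the scatter. In this assay compound 4 is estimated at 100000 nM, with an expected range of 30000 nM to 300000 nM.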

Compound 4, half-maximal inhibitory concentration: 75000 nM
The estimate for compound 4 lay 1.3-fold (0.12 log units) above the measured number; the measured number falls inside the stated range.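

In this assay compound 4 is the only compound shown that gives a number rather than a limit, with 2-chloro-4-fluorophenyl on the carbonyl carbon whose other neighbour is the amide-type nitrogen. The other three compounds remain at a limit: the limit of > 100000 nM in this assay, at which 3 of the 4 values shown sit. The new steps can be read only as floors: an at least 1.3-fold lower number from compound 3 to compound 4 (0.12 log units; that floor lies within the scatter), an at least 1.3-fold lower number from compound 2 to compound 4 (0.12 log units; that floor lies within the scatter) and an at least 1.3-fold lower number from compound 1 to compound 4 (0.12 log units; that floor lies within the scatter). The group at this position can therefore bring the read-out onto the measurable scale, but no step beyond the scatter is shown, and the steps among compound 1, compound 2 and compound 3 cannot be read.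

On these data alone, the true distance of compound 4 from the other three remains open. Also open, as far as these compounds go, is whether an amine, a carboxylic acid or a longer chain at this position would give a stronger number.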